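Three inactive analogues and an untested phenol

The compounds below may be only part of what the source reports. "The series", "measured", "known", "first", "only" and "open" are said of these compounds alone.

Compound 1, `Nc1nc(-c2ccc(CO)cc2)nc2sc(-c3ccccc3)nc12`: in a functional assay on CHO cells for antagonist activity at adenosine receptor A2b (Homo sapiens), read by cAMP accumulation, with a stated time of 10 min (on this read-out lower numbers stand for stronger inhibition and higher numbers for weaker inhibition), compound 1 gives > 30000 nM, a limit of the assay.
Compound 2, `COc1ccc(-c2nc(N)c3nc(-c4ccccc4)sc3n2)cc1`: in this assay compound 2 gives > 30000 nM, again a limit.
Compound 3, `N#Cc1cccc(-c2nc(N)c3nc(-c4ccccc4)sc3n2)c1`: in this assay compound 3 gives > 30000 nM, also a limit.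

All three measured compounds share one core and differ only in the aryl group attached to it, and every one of them sits at the limit of > 30000 nM in this assay, at which 3 of the 3 values shown sit. The three steps between them, a step that the two limits leave unreadable from compound 1 to compound 2, a step that the two limits leave unreadable from compound 1 to compound 3 and a step that the two limits leave unreadable from compound 2 to compound 3, therefore cannot be read in size or direction. Compound 3 thus stands only at a limit, with no number of its own.

Compound 4, `Nc1nc(-c2cccc(O)c2)nc2sc(-c3ccccc3)nc12`, differs from compound 3 by hydroxy in place of cyano on an aromatic carbon. The two measured steps that touch the 3-cyanophenyl group, from compound 1 and from compound 2 to compound 3, are both unreadable, so they give no basis for expecting a readable step in this assay, in either direction. Compound 4 is therefore expected to give about 40000 nM, with a range from 8000 nM to 200000 nM. The expected step that the limit leaves unreadable from compound 3 to compound 4 is accordingly estimated as one that the limit will most likely again leave unreadable.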

Compound 4, half-maximal inhibitory concentration: > 30000 nM
Compound 4: no number, only a limit; the forecaster's own chance of this, stated with the estimate: 75%; the middle value is on the limit's open side.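

In this assay compound 4 gives > 30000 nM, again a limit of the assay. Its steps from compound 1, compound 2 and compound 3 therefore cannot be read: the limit of > 30000 nM in this assay, at which 4 of the 4 values shown sit.

The compounds shown leave open whether any aryl group on the shared core gives a measurable value in this assay, and how far these four compounds actually differ.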